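A few compounds are considered here, and "the series" means these few. Any claim that something is new, unique, unknown or untested is made for them only; others in the source may bear on it.

In a functional assay on DU-145 cells (Homo sapiens) for antiproliferative activity, read by WST assay, with a stated time of 3 days (on this read-out higher numbers stand for weaker inhibition and lower numbers for stronger inhibition), compound 3 (`CCCCCN(CCCCC)CCCOc1c(-c2cc(OC)c(OC)c(OC)c2)oc2ccccc2c1=O`) gives (12300 nM), within the scatter of compound 1 (`CCN(CC)CCCCOc1c(-c2cc(OC)c(OC)c(OC)c2)oc2ccccc2c1=O`) at (13300 nM), and lower than compound 2 (`CCCN(CCC)CCCCOc1c(-c2cc(OC)c(OC)c(OC)c2)oc2ccccc2c1=O`) at (35800 nM). Compound 4 (`CCCCCN(CCCCC)CCCCOc1c(-c2cc(OC)c(OC)c(OC)c2)oc2ccccc2c1=O`) has (dipentylamino)methyl in place of dipentylamino on a saturated chain carbon, three bonds along the chain from an oxygen on an aromatic ring. For the measured compounds named here, no measured step isolates this change. The nearest are modest or within the scatter: (a 2.7-fold higher number from compound 1 to compound 2 (0.43 log units; beyond the scatter)), (a 2.9-fold lower number from compound 2 to compound 3 (0.46 log units; beyond the scatter)) and (a 1.1-fold lower number from compound 1 to compound 3 (0.03 log units; within the scatter)). They give no clear direction, so in this assay the expected step (a 1.3-fold higher number from compound 3 to compound 4 (0.11 log units; within the scatter)) stays within the scatter. The estimate for compound 4 is 16000 nM (expected range 7000 nM to 38000 nM).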

Compound 4, half-maximal inhibitory concentration: 12500 nM
Beside the measured number, compound 4's estimate is 1.3-fold (0.11 log units) above it, and the stated range covers the measured number.
By their numbers in this assay, from the lowest: compounds 3, 4 and 1 (each within the scatter of the next); then compound 2.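

In this assay, (dipentylamino)methyl in place of dipentylamino on this saturated chain carbon leaves the read-out within the scatter (a 1.0-fold higher number from compound 3 to compound 4 (0.01 log units; within the scatter)). At the position four bonds along the chain from the aromatic oxygen, dipentylamino in place of dipropylamino gives a modest step (a 2.9-fold lower number from compound 2 to compound 4 (0.46 log units; beyond the scatter)), whereas dipentylamino in place of diethylamino stays within the scatter (a 1.1-fold lower number from compound 1 to compound 4 (0.03 log units; within the scatter)), so the amine's alkyl chain length sets no steady trend, with compound 2 going against one. No evidence bears on why these steps differ.

As far as these compounds go, whether dibutylamino follows compound 2 or compound 4 remains open. So does the result of a ring amine such as piperidine or morpholine on either chain.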